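The source may hold more compounds than are shown below. What is called first, only, known or untested is meant among the compounds shown, and "the series" means these compounds.

Compound 1 `O=C(CCCCCCc1ccccc1)c1nc(Br)co1` carries a bromo on its five-membered core and, in an assay on isolated protein for inhibition of Fatty-acid amide hydrolase 1 (Rattus norvegicus) (a higher number here means a weaker inhibitor, a lower number a stronger inhibitor), compound 1 gives 3 nM. Among the three measured compounds it sits second highest, close to both neighbours: compound 2 `O=C(CCCCCCc1ccccc1)c1nc(Cl)co1` gives 4 nM, and compound 3 `CC(=O)c1coc(C(=O)CCCCCCc2ccccc2)n1` gives 2 nM. Within the data shown here, the step of a 1.3-fold higher number from compound 1 to compound 2 (0.12 log units; within the scatter) and the step of a 1.5-fold lower number from compound 1 to compound 3 (0.18 log units; within the scatter) both stay inside the scatter, as does a 2.0-fold lower number from compound 2 to compound 3 (0.30 log units; within the scatter), so this series so far shows no movement that can be read as real.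

Compound 4 `O=C(CCCCCCc1ccccc1)c1nc(-c2ccccc2)co1` differs from compound 1 in one place: phenyl in place of bromo on an aromatic carbon. Among the measured compounds shown here, the three measured steps bear on this only loosely, since they swap between a bromo, a chloro and an acetyl on the same aromatic carbon and none of them moves beyond the scatter; no measured compound carries a ring at that position. On that basis the step of a 1.3-fold higher number from compound 1 to compound 4 (0.12 log units; within the scatter) is expected, with no clear direction. Compound 4 is therefore estimated at 4 nM, in a range from 1.5 nM to 12 nM.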

Compound 4, inhibition constant: 65 nM
Beside the measured number, compound 4's estimate is 16-fold (1.21 log units) below it; the whole stated range lies below it.
By their numbers in this assay, from the lowest: compounds 3, 1 and 2 (each within the scatter of the next); then compound 4.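

On the aromatic carbon next to the ring nitrogen, bromo, chloro and acetyl stay within the scatter of one another in this assay, but phenyl does not, with a 22-fold higher number from compound 1 to compound 4 (1.34 log units; beyond the scatter) and a 16-fold higher number from compound 2 to compound 4 (1.21 log units; beyond the scatter) and a 33-fold higher number from compound 3 to compound 4 (1.51 log units; beyond the scatter) all lying well beyond the scatter. This position is therefore not indifferent to what it carries: the flat picture from the first three compounds does not extend to a phenyl ring, and compound 4 alone stands apart from the others. Nothing shown here accounts for this rise in the number.

Going by these compounds, whether a methyl, a cyclohexyl or a pyridyl group on this carbon would stay with bromo, chloro and acetyl or fall with phenyl remains open. So does whether a substituent on the phenyl ring would shift the number in either direction.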